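The source may report more compounds than this note shows. Statements on the series, on what has been measured and on what is new or still open speak of the compounds shown alone.

In an in vitro ADME assay on microsomes from liver (Homo sapiens) for metabolic stability (on this read-out lower numbers stand for slow clearance and higher numbers for fast clearance), two compounds have been measured so far. Compound 1 (`CCc1nc2nc(C)cc(Nc3cccc(Cl)c3)n2n1`) gives 78.3 mL.min-1.g-1. Compound 2 (`Cc1cc(Nc2ccc(S(F)(F)(F)(F)F)cc2)n2nc(C(F)(F)F)nc2n1`) gives < 5 mL.min-1.g-1, which is a limit of the assay and not a number. Its place on the scale is therefore (the limit of < 5 mL.min-1.g-1 in this assay, at which 1 of the 2 values shown sits).

Compound 3 (`CCOc1nc2nc(C)cc(Nc3ccc(S(F)(F)(F)(F)F)cc3)n2n1`) keeps the rest of compound 2 but has ethoxy in place of trifluoromethyl on an aromatic carbon. Among the compounds with values here, no measured pair isolates this change, so the expectation rests on thin ground. Compound 1, which also lacks the trifluoromethyl but differs elsewhere too, gives 78.3 mL.min-1.g-1. An upward step beyond the scatter is expected in this assay, with an at least 4.0-fold higher number from compound 2 to compound 3 (0.60 log units; beyond the scatter) as the estimated size. For compound 3, the estimated clearance is 20 mL.min-1.g-1, with an expected range of 7 mL.min-1.g-1 to 60 mL.min-1.g-1.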

Compound 3, intrinsic clearance in microsomes: < 5 mL.min-1.g-1
Compound 3: only a limit was reported (the forecaster's own chance of this, stated with the estimate: 15%); at least 4.0-fold (0.60 log units) between middle value and limit.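

Compound 3, like compound 2, returns only a limit of the assay and not a number, so no step between compound 2 and compound 3 can be read in this assay; both sit at the same limit: the limit of < 5 mL.min-1.g-1 in this assay, at which 2 of the 3 values shown sit.

The compounds shown leave open whether ethoxy in place of trifluoromethyl on an aromatic carbon changes clearance at all.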